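The compounds below may be only part of what the source reports. "The series", "measured", "known", "first", "only" and "open" are said of these compounds alone.

Working notes on the series. Among the measured compounds shown here, in an assay on Sf9 cells for inhibition of histone-lysine N-methyltransferase EZH2 (Homo sapiens), read by scintillation counting, in the presence of a further agent that is not named here (on this read-out higher numbers stand for weaker inhibition and lower numbers for stronger inhibition), compound 1 `Nc1ncnc2c1ncn2[C@@H]1O[C@H](CSCC[C@H](N)C(=O)NCC2CC2)[C@@H](O)[C@H]1O` gives 60000 nM, and compound 2 `CN1CCn2nc(CNC(=O)[C@@H](N)CCSC[C@H]3O[C@@H](n4cnc5c(N)ncnc54)[C@H](O)[C@@H]3O)cc2C1` gives 50000 nM; compound 2 thus stands within the scatter of the only other number in hand. For the measured compounds named here, the single measured step, a 1.2-fold lower number from compound 1 to compound 2 (0.08 log units; within the scatter), sits on the amide-type nitrogen and changed nothing beyond the scatter. Compound 3 `Nc1ncnc2c1ncn2[C@@H]1O[C@H](CSCC[C@H](N)C(=O)NCc2cc3n(n2)CCN(Cc2ccccc2)C3)[C@@H](O)[C@H]1O` differs from compound 2 by phenyl in place of hydrogen on a saturated chain carbon bound to an amine nitrogen in a ring, a change at a different place, so that step bears on it only indirectly. Compound 3 is therefore expected to show a step of a 1.3-fold lower number from compound 2 to compound 3 (0.10 log units; within the scatter), within the scatter. Compound 3 is estimated at 40000 nM, with a range from 15000 nM to 110000 nM.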

Compound 3, half-maximal inhibitory concentration: 8000 nM
Estimate against measurement, compound 3: 5.0-fold (0.70 log units) above; measured number below the stated range.
By their numbers in this assay, from the lowest: compound 3; then compounds 2 and 1 (each within the scatter of the next).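

In this assay, the saturated chain carbon bound to an amine nitrogen in a ring proves to be a place that responds: phenyl in place of hydrogen there gives a modest step beyond the scatter (a 6.3-fold lower number from compound 2 to compound 3 (0.80 log units; beyond the scatter)), whereas the earlier change on the amide-type nitrogen stayed within it (a 1.2-fold lower number from compound 1 to compound 2 (0.08 log units; within the scatter)). No measured evidence bears on the reason for this step. Open, as far as these compounds go, is whether the aromatic ring itself matters at this place, which cyclohexyl or pyridyl there would test, and whether a longer chain carrying the phenyl would go further.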